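A few compounds are considered here, and "the series" means these few. Any claim that something is new, unique, unknown or untested is made for them only; others in the source may bear on it.

Among the compounds with values here, compound 2 `Fc1cccc(-c2nc(Nc3ccc(Cl)cc3)c3cc(F)ccc3n2)c1` stands at 45700 nM in a functional assay on HL-60 cells (Homo sapiens) for cytotoxicity, read by MTT assay, with a stated time of 48 h (a lower number here means a stronger inhibitor, a higher number a weaker inhibitor), the only number among the values shown. Compound 1 `Fc1cccc(-c2nc(Nc3ccccc3)c3ccccc3n2)c1` gives only a limit in this assay, > 50000 nM, that is the limit of > 50000 nM in this assay, at which 1 of the 2 values shown sits. Compound 3 `Nc1cccc(Nc2nc(-c3cccc(F)c3)nc3ccc(F)cc23)c1` differs from compound 2 by 3-aminophenyl in place of 4-chlorophenyl on a nitrogen on an aromatic ring. Within the data shown here, no step between measured compounds is available for this change, so a step within the usual scatter, in either direction, is what is expected. For compound 3 the estimate in this assay is 50000 nM, with a range from 15000 nM to 150000 nM. The expected step of a 1.1-fold higher number from compound 2 to compound 3 (0.04 log units; within the scatter) is small, and a limit rather than a number is quite possible.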

Compound 3, half-maximal inhibitory concentration: > 50000 nM
Compound 3: only a limit was reported (the forecaster's own chance of this, stated with the estimate: 50%); the middle value sits exactly at the limit.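

In this assay, 3-aminophenyl in place of 4-chlorophenyl on a nitrogen on an aromatic ring gives an at least 1.0-fold higher number from compound 2 to compound 3 (0.03 log units; that floor lies within the scatter). Compound 3 gives only a limit, so this step has a floor but no upper end, and it shows no gain from this change at this position. Most of the values now stand at the same limit: the limit of > 50000 nM in this assay, at which 2 of the 3 values shown sit.

Going by these compounds, how far compound 3 lies past its limit stays open. So does whether a carboxylic acid or a methoxy group on this phenyl ring would give a clear number in this assay.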